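Ethoxy to propoxy on compound 2

A few compounds are considered here, and "the series" means these few. Any claim that something is new, unique, unknown or untested is made for them only; others in the source may bear on it.

For the measured compounds named here, in a functional assay on HT-29 cells (Homo sapiens) for antiproliferative activity, read by MTT assay, with a stated time of 48 h (on this read-out lower numbers stand for stronger inhibition of growth and higher numbers for weaker inhibition of growth), compound 2 `CCOC(=O)N1N=C(c2ccc(OC)cc2)CC1c1cc(OC)c(OC)c(OC)c1` gives 6730 nM, the only actual number so far. Compound 1 `CCCOC(=O)N1N=C(c2cccc(OC)c2)CC1c1cc(OC)c(OC)c(OC)c1` is reported only as a limit of the assay, > 10000 nM. Compound 3 `CCCOC(=O)N1N=C(c2ccc(OC)cc2)CC1c1cc(OC)c(OC)c(OC)c1` takes compound 2 from ethoxy to propoxy, a methyl in place of hydrogen on a saturated chain carbon, two bonds along the chain from an oxygen next to a carbonyl group. Going by the values given here, no measured pair shows the size of such a change in this assay, so little movement is expected, perhaps slightly weaker inhibition of growth. The expected 1.2-fold higher number from compound 2 to compound 3 (0.08 log units; within the scatter) should stay small. For compound 3 the estimated value is 8000 nM, with an expected range of 3500 nM to 10000 nM.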

Compound 3, concentration for 50% growth inhibition: 12700 nM
Compound 3: middle estimate off by 1.6-fold (0.20 log units), on the low side, and the stated range ends below it.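

In this assay, for the compounds shown here, the first readable step at this position, ethoxy to propoxy, gives a 1.9-fold higher number from compound 2 to compound 3 (0.28 log units; within the scatter), so this added methyl does not separate the two compounds on this read-out. The step that links compound 1 to compound 3 cannot be read, as the value of compound 1 is a limit: the limit of > 10000 nM in this assay, at which 1 of the 3 values shown sits.

As far as these compounds go, whether a longer chain such as butoxy, a branched isopropoxy or an amine at this place would separate from compound 2 stays open. Also open, from the compounds shown here alone, is how the 3-methoxyphenyl and 4-methoxyphenyl groups compare.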